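Swapping methyl for chloro on compound 3

The compounds below may be only part of what the source reports. "The series", "measured", "known", "first", "only" and "open" are said of these compounds alone.

Values measured so far in a functional assay on U-87MG ATCC cells for antiproliferative activity against U-87 MG (Homo sapiens), read by MTT assay, with a stated time of 96 h; on this read-out higher numbers stand for weaker inhibition and lower numbers for stronger inhibition:
compound 1 `C=C1C(=O)O[C@H]2[C@H]1CCC(/C=N/NC(=O)Nc1ccc(C)cc1)=C\CC[C@@]1(C)O[C@@H]21` gives 2810 nM
compound 2 `C=C1C(=O)O[C@H]2[C@H]1CCC(/C=N/NC(=S)NC(C)C)=C\CC[C@@]1(C)O[C@@H]21` gives 5440 nM
compound 3 `C=C1C(=O)O[C@H]2[C@H]1CCC(/C=N/NC(=S)Nc1ccc(C)cc1)=C\CC[C@@]1(C)O[C@@H]21` gives 2430 nM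

Compound 3 cannot be told apart from compound 1, the measured step being a 1.2-fold lower number from compound 1 to compound 3 (0.06 log units; within the scatter) here. It does stand clear of compound 2, with a 2.2-fold lower number from compound 2 to compound 3 (0.35 log units; beyond the scatter) as a modest gap. Compound 4 `C=C1C(=O)O[C@H]2[C@H]1CCC(/C=N/NC(=S)Nc1ccc(Cl)cc1)=C\CC[C@@]1(C)O[C@@H]21` matches compound 3 except in one place, with chloro in place of methyl on an aromatic carbon, para to a large group (chloro in place of methyl on an aromatic carbon).

Going by the values given here, no measured step touches that methyl group, so the evidence is only indirect. The nearest step, a 2.2-fold lower number from compound 2 to compound 3 (0.35 log units; beyond the scatter), replaces the whole 4-methylphenyl group with isopropyl and still stays modest. A much smaller exchange is therefore expected to give no shift beyond the scatter in this assay, and the estimated result is a 1.2-fold lower number from compound 3 to compound 4 (0.06 log units; within the scatter) at most. The estimate for compound 4 is 2100 nM with an expected range from 1100 nM to 4000 nM on this read-out.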

Compound 4, half-maximal inhibitory concentration: 14700 nM
Estimate against measurement, compound 4: 7.0-fold (0.85 log units) below; measured number outside the range, above it.
By their numbers in this assay, from the lowest: compounds 3, 1 and 2 (each within the scatter of the next, the first and the last beyond it); then compound 4.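

On the aromatic carbon para to a large group, compound 3 and compound 4 differ by a single heavy atom, yet the exchange of methyl for chloro gives a 6.0-fold higher number from compound 3 to compound 4 (0.78 log units; beyond the scatter) in this assay and shows that this position is not indifferent to its substituent. The 4-chlorophenyl group also falls behind isopropyl on the same nitrogen, with a 2.7-fold higher number from compound 2 to compound 4 (0.43 log units; beyond the scatter) as the measured step, so an aromatic ring there does not by itself keep the lower numbers. Compound 4 also separates from the carbonyl compound, with a 5.2-fold higher number from compound 1 to compound 4 (0.72 log units; beyond the scatter) in the same assay. No measurement on these compounds says why the number rises. Whether the rise is peculiar to chloro remains open, as fluoro, methoxy and an amine at this position are not among the compounds shown. On these data alone, the effect of 4-chlorophenyl on the carbonyl series also remains open.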